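The compounds below may be only part of what the source reports. "The series", "measured", "known", "first", "only" and "open" are said of these compounds alone.

Values in an ADME assay on L02 cells (Homo sapiens) for cytotoxicity, read by MTT assay, with a stated time of 24 h; on this read-out higher numbers stand for weaker inhibition and lower numbers for stronger inhibition:
- compound 1 `N#Cc1ccc(/C=C2\CN(S(=O)(=O)c3ccc(F)cc3)C/C(=C\c3ccc(C#N)cc3)C2=O)cc1`: 18900 nM
- compound 2 `COc1cc(/C=C2\CN(S(=O)(=O)c3ccc(F)cc3)C/C(=C\c3cc(OC)c(OC)c(OC)c3)C2=O)cc(OC)c1OC`: 12100 nM
- compound 3 `COc1cc(/C=C2\CN(S(=O)(=O)c3ccc(NC(C)=O)cc3)C/C(=C\c3cc(OC)c(OC)c(OC)c3)C2=O)cc(OC)c1OC`: 13600 nM

Compound 3, at 13600 nM, lies within the scatter of both other compounds, so it has no separate standing in this assay. The next compound is compound 4 `COc1cc(/C=C2\CN(S(=O)(=O)c3ccc(NC(C)=O)cc3)C/C(=C\c3cccc([N+](=O)[O-])c3)C2=O)cc(OC)c1OC`, and the change is 3-nitrophenyl in place of 3,4,5-trimethoxyphenyl on a double-bonded chain carbon bound to a double-bonded ring carbon.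

For the measured compounds named here, the only measured step, a 1.1-fold higher number from compound 2 to compound 3 (0.05 log units; within the scatter), lies within the scatter but concerns the fluoro and acetamido position, not this one. Going by the values given here, no measured step changes this group alone. The nearest evidence is a pair sharing the fluoro group and differing in both aryl groups: compound 1 gives 18900 nM and compound 2 gives 12100 nM, which also lie within the scatter of each other. No shift beyond the scatter is therefore expected, and the estimated change is a 1.0-fold higher number from compound 3 to compound 4 (0.01 log units; within the scatter). For compound 4 the estimated value is 14000 nM, with an expected range from 7000 nM to 28000 nM.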

Compound 4, half-maximal inhibitory concentration: 15600 nM
Beside the measured number, compound 4's estimate is 1.1-fold (0.05 log units) below it; the measured number falls inside the stated range.
By their numbers in this assay, from the lowest: compounds 2, 3, 4 and 1 (each within the scatter of the next).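

In this assay, for the compounds shown here, the step of a 1.1-fold higher number from compound 3 to compound 4 (0.06 log units; within the scatter) is the first reading of a change at this position alone, on a double-bonded chain carbon bound to a double-bonded ring carbon. Earlier, the aryl groups differed only together, in compound 1 and compound 2, so neither group's contribution could be read separately. Here, 3-nitrophenyl replaces 3,4,5-trimethoxyphenyl on one side only, with the other 3,4,5-trimethoxyphenyl group and the acetamido group held constant, and the numbers stay within the scatter; nothing available accounts for this result.

Still open, on these data alone, is whether an amine or a carboxylic acid on this aryl ring would produce a step beyond the scatter. Also open, as far as these compounds go, is whether the same exchange would read alike at the remaining 3,4,5-trimethoxyphenyl group of compound 4.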